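Pyridinone sulfonamides: trimming the aryl methyl

The source may report more compounds than this note shows. Statements on the series, on what has been measured and on what is new or still open speak of the compounds shown alone.

Measured so far in a functional assay (aorta) for antagonist activity, with Oryctolagus cuniculus as the target; a higher number here means a weaker inhibitor, a lower number a stronger inhibitor:
compound 1, `CCCCc1ccc(CNCc2ccccc2)c(=O)n1Cc1ccc(-c2ccccc2-c2nn[nH]n2)cc1`: 1 nM
compound 2, `CCCCc1ccc(CN(C)S(=O)(=O)c2ccc(C)cc2)c(=O)n1Cc1ccc(-c2ccccc2-c2nn[nH]n2)cc1`: 8 nM

Compound 2 holds the higher of the two numbers in this assay; the step of an 8.0-fold higher number from compound 1 to compound 2 (0.90 log units; beyond the scatter) lies beyond the scatter. Compound 3, `CCCCc1ccc(CN(C)S(=O)(=O)c2ccccc2)c(=O)n1Cc1ccc(-c2ccccc2-c2nn[nH]n2)cc1`, differs from compound 2 by hydrogen in place of methyl on an aromatic carbon. Going by the values given here, no measured step touches this aromatic carbon: the only step known, an 8.0-fold higher number from compound 1 to compound 2 (0.90 log units; beyond the scatter), exchanges the whole group on the chain carbon and so bears on the change only loosely. The expected step is a 1.3-fold higher number from compound 2 to compound 3 (0.10 log units; within the scatter), which is within the scatter. Compound 3 is therefore estimated at 10 nM, in the range 3 nM to 30 nM.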

Compound 3, half-maximal inhibitory concentration: 2 nM
Estimate against measurement, compound 3: 5.0-fold (0.70 log units) above; the whole stated range lies above it.
By their numbers in this assay, from the lowest: compounds 1 and 3 (each within the scatter of the next); then compound 2.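

In this assay, the methyl on the 4-methylphenyl ring is not a neutral substituent: hydrogen in its place gives a 4.0-fold lower number from compound 2 to compound 3 (0.60 log units; beyond the scatter). With phenyl in place of 4-methylphenyl, the sulfonyl group no longer separates from benzylamino beyond the scatter, at a 2.0-fold higher number from compound 1 to compound 3 (0.30 log units; within the scatter). Nothing available explains the cost of the methyl.

Going by these compounds, whether a methoxy group or a chlorine on this same ring carbon would also raise the number remains open. So does whether an ethyl group in place of the methyl on the sulfonyl nitrogen would change it.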